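Replacing the 3-bromo-4-methoxyphenyl group of compound 3

This account rests on a few compounds, and the source may have more. Where it says the series, first, only, none or still open, it means among the compounds named here.

Compound 1 `C[C@H]1CC[C@@H]2[C@@H](OC(=O)[C@]23CC(c2ccc(Br)cc2)N(c2ccccc2)O3)[C@]2(C)C(=O)C=C[C@@]12O`: 4
Compound 2 `Cc1ccccc1C1C[C@@]2(ON1c1ccccc1)C(=O)O[C@@H]1[C@H]2CC[C@H](C)[C@]2(O)C=CC(=O)[C@@]12C`: 3.64
Compound 3 `COc1ccc(C2C[C@@]3(ON2c2ccccc2)C(=O)O[C@@H]2[C@H]3CC[C@H](C)[C@]3(O)C=CC(=O)[C@@]23C)cc1Br`: 3.98

In a physicochemical assay for lipophilicity (a higher number here means a more lipophilic compound, a lower number a more polar compound), compound 3 gives 3.98, level with compound 1 within the scatter: a number 0.02 log units lower from compound 1 to compound 3 (within the scatter). Compound 2 stands apart from both, and the measured step to the last of the three is a number 0.34 log units higher from compound 2 to compound 3 (beyond the scatter).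

The next compound is compound 4 `C[C@H]1CC[C@@H]2[C@@H](OC(=O)[C@]23CC(c2ccccc2Cl)N(c2ccccc2)O3)[C@]2(C)C(=O)C=C[C@@]12O`, not yet measured, which carries 2-chlorophenyl in place of 3-bromo-4-methoxyphenyl on a saturated ring carbon.

Among the measured compounds shown here, none of the measured compounds carries chlorine, so no step shows this change directly. The closest guide is compound 2, whose 2-methylphenyl group differs from 2-chlorophenyl only in having methyl where chlorine stands. Its steps are modest: a number 0.36 log units lower from compound 1 to compound 2 (beyond the scatter), and a number 0.34 log units higher from compound 2 to compound 3 (beyond the scatter). For the measured compounds named here, compound 4 is therefore expected to fall near compound 2, at a modest distance under compound 3, though the single comparison leaves this uncertain.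

The expected change is a number 0.32 log units lower from compound 3 to compound 4 (beyond the scatter).

For compound 4 the estimated value in this assay is 3.66, with an expected range of 3.4 to 3.95.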

Compound 4, partition coefficient: 3.87
Estimate against measurement, compound 4: 0.21 log units below; the measured number falls inside the stated range.
By their numbers in this assay, from the lowest: compounds 2, 4, 3 and 1 (each within the scatter of the next, the first and the last beyond it).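

In this assay, the 2-chlorophenyl group on the saturated ring carbon cannot be told apart from the 3-bromo-4-methoxyphenyl group (a number 0.11 log units lower from compound 3 to compound 4 (within the scatter)) or from the 4-bromophenyl group (a number 0.13 log units lower from compound 1 to compound 4 (within the scatter)), even though it has fewer heavy atoms than the first and carries neither bromine nor the methoxy oxygen. The closest pair, chloro in place of methyl on an aromatic carbon, also stays inside the scatter (a number 0.23 log units higher from compound 2 to compound 4 (within the scatter)), so the earlier separation of compound 2 from the two bromine-bearing compounds no longer reads as a clean split, and the four compounds now form a chain in which only the two ends lie beyond the scatter of each other. Nothing available gives a measured reason for these small differences.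

Going by these compounds, all the groups compared at this position are phenyl rings carrying a halogen, a methyl or a methoxy group, so it remains open whether an amine or a carboxylic acid on that ring would stay within the same narrow span of values. The compounds shown also leave open how chlorine would compare at another place on the ring, as in 4-chlorophenyl, and whether a saturated ring such as cyclohexyl could replace the aromatic ring.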